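Ring Size at the Amine Position of a Quinazoline Series

A few compounds are considered here, and "the series" means these few. Any claim that something is new, unique, unknown or untested is made for them only; others in the source may bear on it.

Measured so far:
Compound 1 `C/C=C/C(=O)Nc1cc2c(N3CCCc4ccccc43)ncnc2cc1O[C@@H]1CCOC1` gives 9350 nM in a functional assay on PC-3 cells (Homo sapiens) for antiproliferative activity, read by MTT assay, with a stated time of 72 h; a higher number here means a weaker inhibitor, a lower number a stronger inhibitor.
Compound 2 `O=C(/C=C/CN1CCCCC1)Nc1cc2c(N3CCc4ccccc43)ncnc2cc1O[C@@H]1CCOC1` gives 4510 nM in this assay.

Compound 2 has the lowest of the two numbers; compound 1 is its nearest neighbour, and the two differ in more than one place, so their values say nothing about a single change. Compound 3 `O=C(/C=C/CN1CCCCC1)Nc1cc2c(N3CCCc4ccccc43)ncnc2cc1O[C@@H]1CCOC1` differs from compound 2 by 1,2,3,4-tetrahydroquinolin-1-yl in place of 2,3-dihydro-1H-indol-1-yl on an aromatic carbon. Going by the values given here, no measured pair shows this change alone, so its effect is unknown. The expected step of a 1.2-fold higher number from compound 2 to compound 3 (0.09 log units; within the scatter) is small, in either direction, likely within the scatter. Compound 3 is estimated at 5500 nM, between 2200 nM and 14000 nM.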

Compound 3, half-maximal inhibitory concentration: 3630 nM
The estimate for compound 3 lay 1.5-fold (0.18 log units) above the measured number; low and high end bracket the measured number.
By their numbers in this assay, from the lowest: compounds 3 and 2 (each within the scatter of the next); then compound 1.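

In this assay the swap of 2,3-dihydro-1H-indol-1-yl for 1,2,3,4-tetrahydroquinolin-1-yl gives a 1.2-fold lower number from compound 2 to compound 3 (0.09 log units; within the scatter) and so, at this position, the five-membered and six-membered non-aromatic rings cannot be told apart. Piperidin-1-yl on the chain gives a 2.6-fold lower number from compound 1 to compound 3 (0.41 log units; beyond the scatter) as a modest step beyond the scatter. No evidence here explains either step.

Going by these compounds alone, the ring swap is seen only with piperidin-1-yl on the chain. On these data alone, whether a seven-membered ring at this position, or morpholin-4-yl or dimethylamino on the chain, would fit the same picture stays open.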